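This account rests on a few compounds, and the source may have more. Where it says the series, first, only, none or still open, it means among the compounds named here.

Measured so far in a functional assay on MCF7 cells (Homo sapiens) for inhibition, read by MTT assay, with a stated time of 48 h; on this read-out lower numbers stand for stronger inhibition and higher numbers for weaker inhibition:
compound 1 `Brc1ccccc1CSc1nnc(-c2ccncc2)n1-c1ccccc1`: 16100 nM
compound 2 `c1ccc(CSc2nnc(-c3ccncc3)n2-c2ccccc2)cc1`: 22400 nM
compound 3 `O=C(CSc1nnc(-c2ccncc2)n1-c1ccccc1)N/N=C/c1ccc(O)cc1`: a limit, > 50000 nM

Compound 3 stands at the limit of > 50000 nM in this assay, at which 1 of the 3 values shown sits, so no number is known for it in this assay. Compound 4 `O=C(CSc1nnc(-c2ccncc2)n1-c1ccccc1)N/N=C/c1cc(Br)ccc1O` carries 5-bromo-2-hydroxyphenyl in place of 4-hydroxyphenyl on a carbon with a double bond to nitrogen, that is 5-bromo-2-hydroxyphenyl in place of 4-hydroxyphenyl on a carbon with a double bond to nitrogen. Among the compounds with values here, the only measured step touching a bromo group, a 1.4-fold higher number from compound 1 to compound 2 (0.14 log units; within the scatter), lies within the scatter and sits on a different part of the series. Nothing measured points to a step beyond the scatter here, so compound 4 is expected to stay close to the limit of compound 3, with a step that the limit leaves unreadable from compound 3 to compound 4 expected to be small. Compound 4 is estimated at 60000 nM, between 25000 nM and 150000 nM, and is most likely reported again as a limit.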

Compound 4, half-maximal inhibitory concentration: 6460 nM
Compound 4: the middle estimate sits 9.3-fold (0.97 log units) above what was measured, outside the stated range (below it).
By their numbers in this assay, from the lowest: compound 4; then compounds 1 and 2 (each within the scatter of the next). At a limit, above all of these: compound 3.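

In this assay, the group on the carbon with a double bond to nitrogen proves able to move the read-out: 5-bromo-2-hydroxyphenyl in place of 4-hydroxyphenyl gives an at least 7.7-fold lower number from compound 3 to compound 4 (0.88 log units; beyond the scatter). The earlier readable step, a 1.4-fold higher number from compound 1 to compound 2 (0.14 log units; within the scatter), lay on a different part of the series and within the scatter. Only a lower bound on the new step can be read, because compound 3 stands at a limit: the limit of > 50000 nM in this assay, at which 1 of the 4 values shown sits.

The change alters both the bromo group and the place of the hydroxy group, and the compounds shown do not separate the two. Going by these compounds, whether a methoxy group or an amine on this phenyl would keep the lower number also stays open.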